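Swapping naphthalen-1-yl for 4-bromophenyl

A few compounds are considered here, and "the series" means these few. Any claim that something is new, unique, unknown or untested is made for them only; others in the source may bear on it.

Values in a functional assay on DU-145 cells (Homo sapiens) for inhibition, read by MTT assay, with a stated time of 72 h; on this read-out higher numbers stand for weaker inhibition and lower numbers for stronger inhibition:
Compound 1 `O=C(CCCCCCC(=O)Nc1ccc(C2=C(c3ccc(O)cc3)C3CC(S(=O)(=O)Oc4ccccc4)C2O3)cc1)NO`: 37700 nM
Compound 2 `O=C(CCCCCCC(=O)Nc1ccc(C2=C(c3ccc(O)cc3)C3CC(S(=O)(=O)Oc4cccc5ccccc45)C2O3)cc1)NO`: 8570 nM

Compound 2 has the lower of the two numbers, making it the stronger inhibitor so far. Compound 3 `O=C(CCCCCCC(=O)Nc1ccc(C2=C(c3ccc(O)cc3)C3CC(S(=O)(=O)Oc4ccc(Br)cc4)C2O3)cc1)NO` has 4-bromophenyl in place of naphthalen-1-yl on an oxygen. Going by the values given here, only one measured step bears on this change: a 4.4-fold lower number from compound 1 to compound 2 (0.64 log units; beyond the scatter), a modest gain on replacing phenyl with naphthalen-1-yl. Compound 3 again has one six-membered aromatic ring there, so part of that gain may be lost, and a modest rise in this assay is expected. The expected change is a 2.2-fold higher number from compound 2 to compound 3 (0.35 log units; beyond the scatter). For compound 3 the estimate is 19000 nM, with an expected range of 7000 nM to 45000 nM.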

Compound 3, half-maximal inhibitory concentration: 11300 nM
Compound 3: the middle estimate sits 1.7-fold (0.23 log units) above what was measured, within the range that was stated.
By their numbers in this assay, from the lowest: compounds 2 and 3 (each within the scatter of the next); then compound 1.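

Compound 3 shows that the second ring of naphthalen-1-yl is not required on this oxygen in this assay: a single ring carrying bromo gives a step within the scatter (a 1.3-fold higher number from compound 2 to compound 3 (0.12 log units; within the scatter)). Adding bromo to the plain phenyl ring is enough on its own for a modest improvement (a 3.3-fold lower number from compound 1 to compound 3 (0.52 log units; beyond the scatter)). Nothing available explains either step. As far as these compounds go, it remains open whether chloro, methoxy or a carboxylic acid in place of bromo would give a similar number, and whether moving bromo elsewhere on the ring would matter.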